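Isopropyl gives way to an ether chain on the shared core

A few compounds are considered here, and "the series" means these few. Any claim that something is new, unique, unknown or untested is made for them only; others in the source may bear on it.

Among the measured compounds shown here, in a functional assay on FaDu cells (Homo sapiens) for cytotoxicity, read by MTT assay, with a stated time of 72 h (a lower number here means that less compound is tolerated, a higher number that more compound is tolerated), compound 2 `COc1ccc(NC(=O)C(=O)c2cn(C(C)C)c3ccccc23)cn1` gives 85 nM, the only exact number so far. Compound 1 `COc1ccc(NC(=O)C(=O)c2cn(C(C)(C)COCC(=O)O)c3ccccc23)cn1` reports > 10000 nM in this assay, which is a limit of the assay and not a number.

Compound 3 `COc1ccc(NC(=O)C(=O)c2cn(CC(C)(C)OC)c3ccccc23)cn1` has not yet been measured. It carries 2-methoxy-2-methylpropyl in place of isopropyl on an aromatic nitrogen, with the shared core otherwise unchanged: 2-methoxy-2-methylpropyl in place of isopropyl on an aromatic nitrogen.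

For the measured compounds named here, only one measured step bears on this change: an at least 110-fold lower number from compound 1 to compound 2 (2.07 log units; beyond the scatter). That step puts hydrogen in place of (carboxymethoxy)methyl on a saturated chain carbon, so it also alters the group on the aromatic nitrogen. However, the group it removes is not the one compound 3 gains, so it offers only a loose guide, and only a small share of its size is expected here.

A modest move toward a higher number in this assay seems most likely, and the expected change is a 1.8-fold higher number from compound 2 to compound 3 (0.25 log units; within the scatter). For compound 3 the estimated value is 150 nM, with an expected range from 40 nM to 600 nM.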

Compound 3, concentration lethal to 50% of the cells: > 10000 nM
Compound 3 was reported as a limit; the forecaster's own chance of this, stated with the estimate: 3%; middle value at least 66-fold (1.82 log units) from the limit.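

Moving from isopropyl to 2-methoxy-2-methylpropyl on the aromatic nitrogen gives, in this assay, an at least 110-fold higher number from compound 2 to compound 3 (2.07 log units; beyond the scatter), so a carboxylic acid such as the one in compound 1 is not needed for a step this large. Going by these compounds, the value of compound 3 is a limit of the assay and not a number, so the step shows only how far the value has moved at the least, and the true distance stays unknown. The step between compound 1 and compound 3 cannot be read, and the two compounds cannot be placed in order: the limit of > 10000 nM in this assay, at which 2 of the 3 values shown sit.

Isopropyl is the only group shown on this nitrogen with an exact value, so the compounds leave open whether the ether oxygen of 2-methoxy-2-methylpropyl or simply the larger group goes with the change. A plain 2-methylpropyl chain with no oxygen, an ethyl group, or a hydroxyl in place of the methoxy would help separate these two readings, and would show where between the exact value and the limit such groups fall.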